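Acetylation of a Second Sugar Hydroxyl in a Glycoside Series

The source may hold more compounds than are shown below. What is called first, only, known or untested is meant among the compounds shown, and "the series" means these compounds.

Three glycosides sharing one core have been measured in a functional assay on HCT-15 cells (Homo sapiens) for cytotoxicity, read by sulforhodamine B assay; a lower number here means that less compound is needed, a higher number that more compound is needed for the effect. Compound 2 `C=C[C@@](C)(CC[C@H]1C(C)=CC[C@H]2C(C)(C)CCC[C@]12C)O[C@@H]1O[C@H](C)[C@H](O)[C@H](O)[C@H]1O` gives 3.9 ug/mL, the second highest of the three numbers. Compound 3 `C=C[C@@](C)(CC[C@H]1C(C)=CC[C@H]2C(C)(C)CCC[C@]12C)O[C@@H]1O[C@H](C)[C@H](OC(C)=O)[C@H](O)[C@H]1O` gives 4.1 ug/mL, and compound 1 `C=C[C@@](C)(CC[C@H]1C(C)=CC[C@H]2C(C)(C)CCC[C@]12C)O[C@@H]1O[C@@H](C)[C@@H](OC(C)=O)[C@H](O)[C@H]1O` gives 3.1 ug/mL. All three values sit within the scatter of one another, so no order among them can be claimed. The step of a 1.1-fold higher number from compound 2 to compound 3 (0.02 log units; within the scatter) comes from acetyl in place of hydrogen on an oxygen on a saturated carbon. The step of a 1.3-fold higher number from compound 1 to compound 3 (0.12 log units; within the scatter) separates two compounds that differ only in configuration as drawn (the fact that compounds 1 and 3 differ only in the configuration as drawn).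

Compound 4 `C=C[C@@](C)(CC[C@H]1C(C)=CC[C@H]2C(C)(C)CCC[C@]12C)O[C@@H]1O[C@H](C)[C@H](O)[C@H](OC(C)=O)[C@H]1O` differs from compound 2 by acetyl in place of hydrogen on an oxygen on a saturated carbon. Going by the values given here, the only measured step of the same kind, a 1.1-fold higher number from compound 2 to compound 3 (0.02 log units; within the scatter), stayed within the scatter, and no other measured step bears on this change. The expected step is therefore a 1.0-fold higher number from compound 2 to compound 4 (0.01 log units; within the scatter), with no movement beyond the scatter in either direction. Compound 4 is estimated at 4 ug/mL, in a range from 2.5 ug/mL to 6.5 ug/mL.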

Compound 4, concentration for half-maximal effect: 3.8 ug/mL
Compound 4: middle estimate off by 1.1-fold (0.02 log units), on the high side, within the range that was stated.
By their numbers in this assay, from the lowest: compounds 1, 4, 2 and 3 (each within the scatter of the next).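

In this assay, hydroxy to acetoxy at this position gives a 1.0-fold lower number from compound 2 to compound 4 (0.01 log units; within the scatter) and so stays within the scatter, as a 1.1-fold higher number from compound 2 to compound 3 (0.02 log units; within the scatter) did at the other oxygen. Acetyl in place of hydrogen has now been read at two oxygens of the sugar rather than one, and among compounds 2, 3 and 4 neither placement moves the number beyond the scatter.

As far as these compounds go, it remains open whether a longer acyl chain such as hexanoyl, an amine or a carboxylic acid on this oxygen would also leave the number within the scatter, and what acetyl on both oxygens at once would do. Nothing at hand bears on why the numbers of compound 2 and compound 4 stay so close.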